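Quinolin-2-yl on the exocyclic alkene of compound 2

This account rests on a few compounds, and the source may have more. Where it says the series, first, only, none or still open, it means among the compounds named here.

Among the compounds with values here, the series so far holds two measured compounds. Compound 1 `O=C1N=C(N2CCC[C@H]2C(=O)Nc2ccc3ncnc(Nc4cccc(Cl)c4)c3c2)S/C1=C/c1ccc(-c2ccccc2)cc1` in a functional assay on HepG2 cells (Homo sapiens) for antiproliferative activity, read by MTT assay (a higher number here means a weaker inhibitor, a lower number a stronger inhibitor), gives 15400 nM. Compound 2 `O=C1N=C(N2CCC[C@H]2C(=O)Nc2ccc3ncnc(Nc4cccc(Cl)c4)c3c2)S/C1=C/c1cccs1` in this assay gives 4120 nM, the lowest of the two numbers, the other being that of compound 1. Within the data shown here, the only measured step, a 3.7-fold lower number from compound 1 to compound 2 (0.57 log units; beyond the scatter), shows that a smaller single aromatic ring in that position went with a lower number than the larger two-ring group.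

Compound 3 `O=C1N=C(N2CCC[C@H]2C(=O)Nc2ccc3ncnc(Nc4cccc(Cl)c4)c3c2)S/C1=C/c1ccc2ccccc2n1` is not yet measured. It differs from compound 2 in one place: quinolin-2-yl in place of thiophen-2-yl on a double-bonded chain carbon bound to a double-bonded ring carbon. Among the measured compounds shown here, the entering group is again a fused two-ring aromatic system, close in size to the 4-phenylphenyl of compound 1, so the single step that bears on this change, a 3.7-fold lower number from compound 1 to compound 2 (0.57 log units; beyond the scatter), points back toward a higher number, but a quinolin-2-yl is not a 4-phenylphenyl, and one step is thin evidence. A modest rise in this assay is therefore expected, a 2.2-fold higher number from compound 2 to compound 3 (0.34 log units; beyond the scatter), with wide uncertainty. Compound 3 is estimated at 9000 nM, within a range of 3500 nM to 25000 nM.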

Compound 3, half-maximal inhibitory concentration: 22900 nM
Estimate against measurement, compound 3: 2.5-fold (0.41 log units) below; the measured number falls inside the stated range.
By their numbers in this assay, from the lowest: compound 2; then compounds 1 and 3 (each within the scatter of the next).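

In this assay, within the data shown here, the change from thiophen-2-yl to quinolin-2-yl gives a 5.6-fold higher number from compound 2 to compound 3 (0.74 log units; beyond the scatter) on the double-bonded chain carbon bound to a double-bonded ring carbon, so a second group with two aromatic rings also stands well above the single five-membered ring of compound 2. The exchange of the two larger groups gives a 1.5-fold higher number from compound 1 to compound 3 (0.17 log units; within the scatter) and so separates neither group from the other, even though quinolin-2-yl carries a ring nitrogen and 4-phenylphenyl has only carbon in its rings. No further measurement is available to explain why thiophen-2-yl goes with the lowest number here.

Among these compounds, with only one single-ring group in the set, compound 2 alone cannot show whether its lower number goes with having one ring, with the five-membered ring or with the sulfur atom. A phenyl or furan-2-yl group at this place would help to separate those possibilities, while a saturated cyclohexyl group would test whether an aromatic ring is needed there at all.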